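Amide nitrogen substituent change in a calcium channel series

The source may report more compounds than this note shows. Statements on the series, on what has been measured and on what is new or still open speak of the compounds shown alone.

Measured compounds:
Compound 1 `O=C1N(Cc2ccc(Cl)cc2)CCC12CCN(S(=O)(=O)c1ccc(F)cc1)CC2`: 54% in a functional assay on cells for antagonist activity at Voltage-dependent N-type calcium channel subunit alpha-1B (Homo sapiens), read by patch clamp, tested at 3 uM; on this read-out lower numbers stand for less inhibition and higher numbers for more inhibition at the one concentration tested (going by the name of the read-out)
Compound 2 `CC(C)OCCCN1CCC2(CCN(C(c3ccc(F)cc3)c3ccc(F)cc3)CC2)C1=O`: 56%

In this assay compound 1 gives 54% and compound 2 gives 56%. Compound 2 holds the higher of the two numbers, but its nearest neighbour, compound 1, lies within the scatter, so the two cannot be ordered. Within the data shown here, no pair of measured compounds differs in one place only, so the series does not yet show how any single change moves the read-out.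

Compound 3 `CC(C)N1CCC2(CCN(C(c3ccc(F)cc3)c3ccc(F)cc3)CC2)C1=O` awaits measurement in this assay. It differs from compound 2 in one place: isopropyl in place of 3-isopropoxypropyl on an amide-type nitrogen in a ring. Among the measured compounds shown here, no measured step of this kind exists, so the direction rests on the structural change alone.

The expected step is a number 8 percentage points lower from compound 2 to compound 3 (within the scatter), small and, if anything, toward less inhibition, not clearly beyond the scatter. Compound 3 is therefore estimated at 48%, with a range from 28% to 68%.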

Compound 3, a percentage reported as inhibition, at one concentration (the size of the read-out at that concentration, not a potency): 52%
Estimate against measurement, compound 3: 4 percentage points below; the range from low to high includes it.
By their numbers in this assay, from the lowest: compounds 3, 1 and 2 (each within the scatter of the next).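

In this assay, among these compounds, replacing 3-isopropoxypropyl with isopropyl on the amide-type nitrogen in the five-membered ring gives the first single-place step: a number 4 percentage points lower from compound 2 to compound 3 (within the scatter). For this pair, at the one concentration tested, the read-out does not separate the smaller isopropyl from the larger substituent with its ether oxygen, so neither that oxygen nor the extra chain length shows a measurable contribution here. No supporting evidence is available to explain this result.

This pair does not show whether an amine or a carboxylic acid at the end of a chain on this nitrogen would move the read-out beyond the scatter. A single-concentration percentage also leaves open whether compound 2 and compound 3 would remain indistinguishable at other concentrations.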